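Swapping Methyl for Chloro at the Assay Limit

The source may report more compounds than this note shows. Statements on the series, on what has been measured and on what is new or still open speak of the compounds shown alone.

In a functional assay on NCI-H460 cells (Homo sapiens) for antiproliferative activity, read by MTT assay, with a stated time of 48 h (on this read-out lower numbers stand for stronger inhibition and higher numbers for weaker inhibition), compound 1 `CCCCC1(O)C(=O)Nc2ccc(Nc3ccc(C)cc3)cc21` gives 31800 nM and compound 3 `Cc1ccc(Nc2ccc3c(c2)C(O)(Cc2ccccc2)C(=O)N3)cc1` gives 31600 nM. Compound 2 `CCCCCC1(O)C(=O)Nc2ccc(Nc3ccc(C)cc3)cc21` gives no number, only a limit: > 100000 nM. The measured steps among these three all lie in the side chain: an at least 3.1-fold higher number from compound 1 to compound 2 (0.49 log units; beyond the scatter), an at least 3.1-fold lower number from compound 2 to compound 3 (0.50 log units; beyond the scatter) and a 1.0-fold lower number from compound 1 to compound 3 (0.00 log units; within the scatter).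

Compound 4 `CCCCCC1(O)C(=O)Nc2ccc(Nc3ccc(Cl)cc3)cc21` keeps the chain of compound 2 and changes one group: chloro in place of methyl on an aromatic carbon. This is chloro in place of methyl on an aromatic carbon, para to a large group. Going by the values given here, all three measured compounds carry the methyl, so no measured step shows the size of this change directly. The side-chain steps serve only as a rough guide to what counts as a sizeable move in this assay. From the position of compound 2 at its limit, a modest move to a lower number is expected, though the result may again be only a limit. The estimated change is an at least 1.6-fold lower number from compound 2 to compound 4 (0.22 log units; that floor lies within the scatter). For compound 4 the estimated value is 60000 nM, with an expected range of 20000 nM to 100000 nM.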

Compound 4, half-maximal inhibitory concentration: 40800 nM
For compound 4 the middle estimate is 1.5-fold (0.17 log units) above the measured one; the measured number falls inside the stated range.
By their numbers in this assay, from the lowest: compounds 3, 1 and 4 (each within the scatter of the next). At a limit, above all of these: compound 2.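

Compound 2 stands only at a limit, not at a number: the limit of > 100000 nM in this assay, at which 1 of the 4 values shown sits. Chloro in place of methyl on the aromatic carbon gives an at least 2.4-fold lower number from compound 2 to compound 4 (0.38 log units; beyond the scatter), the only step shown at this position, and as it starts from a limit, it gives a floor for the change and not its full size. It also shows that, in this assay, the chain of compound 2 does not by itself hold a compound at the limit, since with chloro in this place the same chain gives a measured number.

Going by these compounds, it remains open whether chloro would shift the number in the same way on the side chains of compound 1 or compound 3. On these data alone, how a bromo, methoxy or trifluoromethyl group on this same aromatic carbon would read also remains open.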